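This account rests on a few compounds, and the source may have more. Where it says the series, first, only, none or still open, it means among the compounds named here.

Compound 1 `O=C(NCc1cc(Cl)ccc1-n1cnnn1)[C@@H]1C[C@@H]2C[C@@H]2N1C(=O)[C@H](O)CC1CC1` gives 3.6 10^-6 cm/s in an ADME assay on Caco-2 cells (Homo sapiens) for permeability, read by LC-MS, in the apical to basolateral direction, with a stated time of 60 min, at pH 6.5; on this read-out higher numbers stand for higher permeability and lower numbers for lower permeability.
Compound 2 `CC(C)(C)OC[C@@H](O)C(=O)N1[C@H](C(=O)NCc2cc(Cl)ccc2-n2cnnn2)C[C@@H]2C[C@@H]21` gives 4.5 10^-6 cm/s.
Compound 3 `CC(C)(C)OC[C@@H](O)C(=O)N1C[C@@H]2C[C@@H]2[C@H]1C(=O)NCc1cc(Cl)ccc1-n1cnnn1` gives 17 10^-6 cm/s.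

Compound 4 `O=C(NCc1cc(Cl)ccc1-n1cnnn1)[C@@H]1[C@H]2C[C@H]2CN1C(=O)[C@H](O)CC1CC1` is not yet measured. Compound 2 and compound 3 share the same atoms joined differently, and the difference between their two cores is not broken down here; compound 3 gives the highest number of the three. Compound 1 arises from compound 2 by cyclopropyl in place of tert-butoxy on a saturated chain carbon, two bonds along the chain from a carbonyl carbon and an oxygen on a saturated carbon, and that step measured a 1.3-fold lower number from compound 2 to compound 1 (0.10 log units; within the scatter). The change from compound 3 to compound 4 is the same change, (cyclopropyl in place of tert-butoxy on a saturated chain carbon, two bonds along the chain from a carbonyl carbon and an oxygen on a saturated carbon), made on the core of compound 3 instead. The same small effect is expected again, a step of a 1.2-fold lower number from compound 3 to compound 4 (0.08 log units; within the scatter), resting on the earlier step of a 1.3-fold lower number from compound 2 to compound 1 (0.10 log units; within the scatter) in this assay . Compound 4 is therefore estimated at 14 10^-6 cm/s, likely between 7 10^-6 cm/s and 28 10^-6 cm/s.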

Compound 4, apparent permeability: 3.4 10^-6 cm/s
Compound 4: the middle estimate sits 4.1-fold (0.61 log units) above what was measured; measured number outside the range, below it.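

In this assay, putting cyclopropyl in place of tert-butoxy on the core of compound 3 gives a clear drop, with a 5.0-fold lower number from compound 3 to compound 4 (0.70 log units; beyond the scatter). The size of this change therefore does not carry over from one core to the other, and a step read on one core is a poor guide to the same step on the other: the same change on two cores in this assay, a 1.3-fold lower number (0.10 log units; within the scatter) from compound 2 to compound 1 and a 5.0-fold lower number (0.70 log units; beyond the scatter) from compound 3 to compound 4, 4.0-fold (0.60 log units) apart, beyond the scatter of two such steps These four compounds show that the step differs between the two cores, but not why it differs, and two cores cannot show how the change would behave on a third.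

Going by these compounds, it remains open whether other groups in the same place, such as an amine, a carboxylic acid or a longer chain, would also separate the two cores.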